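The source may report more compounds than this note shows. Statements on the series, on what has been measured and on what is new or still open speak of the compounds shown alone.

Measured in a functional assay on LNCaP cells (Homo sapiens) for antiproliferative activity, read by propidium iodide staining, with a stated time of 96 h; a lower number here means a stronger inhibitor, a higher number a weaker inhibitor:
compound 1 `CC(O)(COc1ccc(S(F)(F)(F)(F)F)cc1)C(=O)Nc1ccc([N+](=O)[O-])c(C(F)(F)F)c1`: 100000 nM
compound 2 `CC(O)(COc1cccc(S(F)(F)(F)(F)F)c1)C(=O)Nc1ccc(S(F)(F)(F)(F)F)cc1`: 12000 nM
compound 3 `CC(O)(COc1cccc(C(F)(F)F)c1)C(=O)Nc1ccc(S(F)(F)(F)(F)F)cc1`: 24700 nM

Compound 3, at 24700 nM, stands second highest of the three numbers, above compound 2 and below compound 1. Compound 4 `CC(O)(COc1ccccc1C(F)(F)F)C(=O)Nc1ccc(S(F)(F)(F)(F)F)cc1` has 2-(trifluoromethyl)phenyl in place of 3-(trifluoromethyl)phenyl on an oxygen on a saturated carbon. For the measured compounds named here, the one measured step in this part of the molecule is a 2.1-fold higher number from compound 2 to compound 3 (0.31 log units; beyond the scatter). It is modest and exchanges one group for another without moving a group, so it gives no direction here. No step beyond the scatter is expected in this assay, though the uncertainty is wide. The expected step is a 1.0-fold higher number from compound 3 to compound 4 (0.01 log units; within the scatter). Compound 4 is estimated at 25000 nM, with an expected range of 10000 nM to 60000 nM.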

Compound 4, half-maximal inhibitory concentration: 1200 nM
Compound 4: the middle estimate sits 21-fold (1.32 log units) above what was measured; measured number below the stated range.
By their numbers in this assay, from the lowest: compound 4; then compound 2; then compound 3; then compound 1.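

In this assay, 2-(trifluoromethyl)phenyl in place of 3-(trifluoromethyl)phenyl on the oxygen gives a 21-fold lower number from compound 3 to compound 4 (1.31 log units; beyond the scatter). Where the group sits on this ring therefore matters here, even with the atoms unchanged, and this step is far larger than the group exchange a 2.1-fold higher number from compound 2 to compound 3 (0.31 log units; beyond the scatter). No supporting measurement is available to account for the step.

As far as these compounds go, it remains open whether a 2-chlorophenyl or 2-methoxyphenyl group at this place would keep the lower number. From the compounds shown here alone, it is also open whether 2-(pentafluorosulfanyl)phenyl would do so.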